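Methyl for hydrogen on the phenyl of compound 1

The compounds below may be only part of what the source reports. "The series", "measured", "known", "first", "only" and "open" are said of these compounds alone.

Measured in a functional assay on NCI-H460 cells (Homo sapiens) for inhibition, read by CCK-8 assay, with a stated time of 48 h; on this read-out higher numbers stand for weaker inhibition and lower numbers for stronger inhibition:
compound 1 `O=C(NC(=S)Nc1ccc(F)cc1)c1cn(-c2ccccc2)nc1-c1ccccc1` gives 4210 nM
compound 2 `COc1ccc(-c2nn(-c3ccccc3)cc2C(=O)NC(=S)Nc2ccc(Cl)cc2)cc1` gives 3010 nM
compound 3 `O=C(NC(=S)Nc1ccc(Cl)cc1)c1cn(-c2ccccc2)nc1-c1ccccc1` gives 4020 nM

Compound 1 sits among the three numbers with nothing to separate it from the others: its gap to compound 3 is a 1.0-fold lower number from compound 1 to compound 3 (0.02 log units; within the scatter), and its number lies within the scatter of compound 2 as well. The three compounds are, on this read-out, indistinguishable.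

Compound 4 `Cc1ccc(-c2nn(-c3ccccc3)cc2C(=O)NC(=S)Nc2ccc(F)cc2)cc1` is not yet measured. It differs from compound 1 by methyl in place of hydrogen on an aromatic carbon, the place being on an aromatic carbon of a six-membered aromatic ring of carbon only, para to a large group.

Among the measured compounds shown here, two measured steps bear on this. The step from compound 2 to compound 3, hydrogen in place of methoxy at the same place, reads a 1.3-fold higher number from compound 2 to compound 3 (0.13 log units; within the scatter). The step from compound 1 to compound 3, chloro in place of fluoro on the other aromatic ring, reads a 1.0-fold lower number from compound 1 to compound 3 (0.02 log units; within the scatter). Both are within the scatter, so a small substituent at this place has so far done nothing that the assay can resolve.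

Compound 4 is therefore expected to give a step of a 1.1-fold lower number from compound 1 to compound 4 (0.03 log units; within the scatter) in this assay, no change beyond the scatter. The estimate for compound 4 is 3900 nM, with a range from 2000 nM to 7600 nM.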

Compound 4, half-maximal inhibitory concentration: 3980 nM
Estimate against measurement, compound 4: 1.0-fold (0.01 log units) below; low and high end bracket the measured number.
By their numbers in this assay, from the lowest: compounds 2, 4, 3 and 1 (each within the scatter of the next).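

In this assay, the change from phenyl to 4-methylphenyl on the core of compound 1 gives a 1.1-fold lower number from compound 1 to compound 4 (0.02 log units; within the scatter) and adds a direct reading at this place with the fluoro group on the other aromatic ring held constant. Until now, this place had been read only through the exchange of methoxy for hydrogen in the chloro pair, compounds 2 and 3, so the lack of a resolved step now extends to methyl in the fluoro pair, compounds 1 and 4. No measurement at hand offers an explanation for the absence of a resolved change at this place.

The compounds shown carry only hydrogen, methyl and methoxy at this place, so it remains open whether an amine, a carboxylic acid or a longer chain such as butyl would move the number beyond the scatter. The other aromatic ring carries only fluoro or chloro, which leaves open how a nitrile or a trifluoromethyl there would read, alone or combined with methyl.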